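A few compounds are considered here, and "the series" means these few. Any claim that something is new, unique, unknown or untested is made for them only; others in the source may bear on it.

Compound 2, `COC(=O)c1ccc(NCc2cncn2Cc2cccc(C#N)c2)cc1-c1ccccc1`, was examined in a toxicity assay on NIH3T3 cells (Mus musculus) for cytotoxicity, read by resazurin assay; on this read-out lower numbers stand for an effect already at smaller amounts and higher numbers for an effect only at larger amounts of compound. In this assay compound 2 gives > 10000 nM, which is a limit of the assay and not a number. Compound 1, `COC(=O)c1ccc(NCc2cncn2Cc2ccc(C#N)cc2)cc1-c1ccccc1`, carries a 4-cyanophenyl where compound 2 carries a 3-cyanophenyl on a saturated chain carbon bound to an aromatic nitrogen. In this assay compound 1 gives > 10000 nM, also a limit. The step that the two limits leave unreadable from compound 1 to compound 2 therefore has no readable size, because of the limit of > 10000 nM in this assay, at which 2 of the 2 values shown sit.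

Compound 3, `COC(=O)c1ccc(NCc2cncn2Cc2ccc(Cl)cc2)cc1-c1ccccc1`, has not yet been measured. It differs from compound 2 by 4-chlorophenyl in place of 3-cyanophenyl on a saturated chain carbon bound to an aromatic nitrogen. Within the data shown here, the only measured step at this position is unreadable, so no direction or size beyond the scatter can be drawn from it, and the expectation is that compound 3 stays where compound 2 stands, with a step that the limit leaves unreadable from compound 2 to compound 3 expected. In this assay compound 3 is estimated at 20000 nM, most likely between 8000 nM and 60000 nM.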

Compound 3, half-maximal effective concentration: 25000 nM
The estimate for compound 3 lay 1.3-fold (0.10 log units) below the measured number; the measured number falls inside the stated range.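

No step from compound 1 or compound 2 to compound 3 can be read in this assay, because compound 1 and compound 2 give only a limit and not a number: the limit of > 10000 nM in this assay, at which 2 of the 3 values shown sit.

The compounds shown leave open whether compound 1, compound 2 and compound 3 truly differ from one another in cytotoxicity.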